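Trifluoromethyl on a weak growth inhibitor

A few compounds are considered here, and "the series" means these few. Any claim that something is new, unique, unknown or untested is made for them only; others in the source may bear on it.

Compound 1 `c1ccc(-c2ccc(-c3ccc(-c4nc5ccccc5[nH]4)cc3)cc2)cc1`: 32100 nM
Compound 2 `Cc1ccc2[nH]c(-c3ccc(-c4ccc(-c5ccc(N(C)C)cc5)cc4)cc3)nc2c1`: 2210 nM
Compound 3 `COc1cc(-c2ccc(-c3ccc(-c4nc5cc(C)ccc5[nH]4)cc3)cc2)cc(OC)c1OC`: 190 nM

In a functional assay on A2780 cells (Homo sapiens) for inhibition, read by sulforhodamine B assay (on this read-out lower numbers stand for stronger inhibition of growth and higher numbers for weaker inhibition of growth), compound 1 gives 32100 nM as the highest of the three numbers, and its gaps to compound 2 and compound 3 both lie beyond the scatter. Compound 4 `FC(F)(F)c1ccc(-c2ccc(-c3ccc(-c4nc5ccccc5[nH]4)cc3)cc2)cc1` has not yet been measured. It differs from compound 1 in one place: trifluoromethyl in place of hydrogen on an aromatic carbon, which means trifluoromethyl in place of hydrogen on an aromatic carbon, para to a large group.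

Among the compounds with values here, no measured pair shows a single change like this one. Compound 2 at 2210 nM and compound 3 at 190 nM differ from compound 1 in more than one place, yet both carry added groups and both sit lower. A moderate move toward stronger inhibition of growth therefore seems likelier than no change. The expected step is a 3.6-fold lower number from compound 1 to compound 4 (0.55 log units; beyond the scatter) and it remains uncertain. Compound 4 is estimated at 9000 nM with an expected range from 1500 nM to 40000 nM as the likely span.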

Compound 4, concentration for 50% growth inhibition: 100000 nM
For compound 4 the middle estimate is 11-fold (1.05 log units) below the measured one; measured number above the stated range.
By their numbers in this assay, from the lowest: compound 3; then compound 2; then compound 1; then compound 4.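

In this assay, changing phenyl to 4-(trifluoromethyl)phenyl gives a 3.1-fold higher number from compound 1 to compound 4 (0.49 log units; beyond the scatter), which is a move toward weaker inhibition of growth. This is the first change in a single place among the compounds shown, and it shows that adding a group at this aromatic carbon does not by itself bring stronger inhibition; with trifluoromethyl, the effect runs the other way. No measurement at hand gives a reason for this loss.

The compounds shown do not tell whether a single fluorine, a hydroxyl or a carboxylic acid on this same carbon would also weaken inhibition of growth. They also leave open whether trifluoromethyl would have the same effect in compound 2 or compound 3, which differ from compound 1 in more than one place.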